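The source may report more compounds than this note shows. Statements on the series, on what has been measured and on what is new or still open speak of the compounds shown alone.

Working notes on the series. In a functional assay on BT-474 cells (Homo sapiens) for inhibition, read by fluorescence, with a stated time of 72 h (a higher number here means a weaker inhibitor of growth, a lower number a stronger inhibitor of growth), compound 1 (`CCCCn1cnc2c(NCc3cccc(Cl)c3)nc(N[C@H]3CC[C@H](N)CC3)nc21`) gives 4700 nM and compound 2 (`CCCCCCn1cnc2c(Nc3cc(OC)cc(OC)c3)nc(N[C@H]3CC[C@H](N)CC3)nc21`) gives 3700 nM. For the measured compounds named here, these two values lie within the scatter of each other, and compound 2 stands level with the only other measured compound. Compound 3 (`CCCCn1cnc2c(Nc3cc(OC)cc(OC)c3)nc(N[C@H]3CC[C@H](N)CC3)nc21`) differs from compound 2 in one place: hydrogen in place of ethyl on a saturated chain carbon, four bonds along the chain from an aromatic nitrogen. Going by the values given here, no measured pair isolates this change in this assay. Compound 1 carries the same chain as compound 3 on a different remainder, and compound 1 gives 4700 nM. No step beyond the scatter is expected, in either direction: the estimated 1.1-fold higher number from compound 2 to compound 3 (0.03 log units; within the scatter) stays small. For compound 3 the expected value is 4000 nM, with an estimated range of 1800 nM to 9000 nM.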

Compound 3, concentration for 50% growth inhibition: 15600 nM
Estimate against measurement, compound 3: 3.9-fold (0.59 log units) below; measured number above the stated range.
By their numbers in this assay, from the lowest: compounds 2 and 1 (each within the scatter of the next); then compound 3.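

In this assay, for the compounds shown here, the position four bonds along the chain from an aromatic nitrogen proves sensitive: hydrogen in place of ethyl on that saturated chain carbon gives a 4.2-fold higher number from compound 2 to compound 3 (0.62 log units; beyond the scatter), the first step beyond the scatter. With the chain held constant, 3,5-dimethoxyphenyl in place of 3-chlorobenzyl on a nitrogen on an aromatic ring gives a 3.3-fold higher number from compound 1 to compound 3 (0.52 log units; beyond the scatter), so the group on that nitrogen also matters at this chain length. Nothing at hand bears on the cause of either step.

The compounds shown leave open whether the chain step holds when 3-chlorobenzyl replaces 3,5-dimethoxyphenyl. They also leave open whether a still longer chain, or a chain ending in an amine or a carboxylic acid, would continue or reverse the step.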